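Aryl variation on the shared core: growth inhibition notes

The source may hold more compounds than are shown below. What is called first, only, known or untested is meant among the compounds shown, and "the series" means these compounds.

Measured so far:
compound 1 `COc1ccc(Nc2ncc(C(F)(F)F)c(N3Cc4cccc(N(C)S(C)(=O)=O)c4C3)n2)cc1C(F)(F)F` — > 30000 nM
compound 2 `COc1cc(Nc2ncc(C(F)(F)F)c(N3Cc4cccc(N(C)S(C)(=O)=O)c4C3)n2)cc(OC)c1` — 1800 nM

In a functional assay on HepG2 cells (Homo sapiens) for antiproliferative activity, read by spectrophotometry, with a stated time of 2 days (on this read-out higher numbers stand for weaker inhibition of growth and lower numbers for stronger inhibition of growth), compound 1 sits at the limit of > 30000 nM in this assay, at which 1 of the 2 values shown sits; its value, > 30000 nM, is a limit of the assay and not a number. Compound 2 gives 1800 nM in this assay. Among the compounds with values here, the single measured step, an at least 16-fold lower number from compound 1 to compound 2 (1.22 log units; beyond the scatter), shows that the aryl group on the nitrogen on an aromatic ring matters strongly for growth inhibition.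

Compound 3 `CN(c1cccc2c1CN(c1nc(Nc3cc(Cl)cc(C(F)(F)F)c3)ncc1C(F)(F)F)C2)S(C)(=O)=O` is not yet measured. It differs from compound 1 by 3-chloro-5-(trifluoromethyl)phenyl in place of 4-methoxy-3-(trifluoromethyl)phenyl on a nitrogen on an aromatic ring. Within the data shown here, the measured step bears on it only in that it changes the same place; the entering group is neither the one that left compound 1 nor the one that entered compound 2, so the direction is open. Compound 3 is therefore expected to improve somewhat on compound 1, with wide uncertainty. The estimate for compound 3 is 10000 nM, between 2000 nM and 60000 nM. The expected step is an at least 3.0-fold lower number from compound 1 to compound 3 (0.47 log units; beyond the scatter).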

Compound 3, concentration for 50% growth inhibition: 9900 nM
The estimate for compound 3 lay 1.0-fold (0.00 log units) above the measured number; the measured number falls inside the stated range.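

In this assay, 3-chloro-5-(trifluoromethyl)phenyl on the nitrogen gives an at least 3.0-fold lower number from compound 1 to compound 3 (0.48 log units; beyond the scatter), so a trifluoromethyl group on the aryl ring does not by itself fix the read-out at the limit. Compound 1 remains a limit and not a number, and the size of this step has only a lower bound: the limit of > 30000 nM in this assay, at which 1 of the 3 values shown sits.

The same entering group gives a 5.5-fold higher number from compound 2 to compound 3 (0.74 log units; beyond the scatter), which leaves compound 2 the strongest of the three, with compound 3 in an intermediate place.

Each step replaces the whole aryl group, so the separate contributions of the chlorine, methoxy and trifluoromethyl substituents cannot be told apart. From the compounds shown here alone, how an aryl group carrying an amine or a carboxylic acid would read in this assay also stays open.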